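The source may report more compounds than this note shows. Statements on the series, on what has been measured and on what is new or still open speak of the compounds shown alone.

Working notes on the series. Compound 1 `Cc1ccnc2nc(-c3cccc4ccccc34)cc(O)c12` is the parent. In a functional assay on MDA-MB-435 cells (Homo sapiens) for antiproliferative activity (a higher number here means a weaker inhibitor of growth, a lower number a stronger inhibitor of growth), compound 1 gives < 10 nM, which is a limit of the assay rather than a number, as stated in the limit of < 10 nM in this assay, at which 1 of the 3 values shown sits. Compound 2 `Cc1cc(C)c2c(O)cc(-c3cccc4ccccc34)nc2n1` carries the change methyl in place of hydrogen on an aromatic carbon and gives 191 nM in this assay; the step of an at least 19-fold higher number from compound 1 to compound 2 (1.28 log units; beyond the scatter) is large. Compound 3 `Cc1ccc2c(O)cc(-c3ccc4ccccc4c3)nc2n1` has the same atoms as compound 1 joined differently; the difference between the two cores is not broken down here. In this assay, for the measured compounds named here, compound 3 gives 1580 nM, the highest number measured so far. Compound 4 `Cc1cc(C)c2c(O)cc(-c3ccc4ccccc4c3)nc2n1` is not yet measured; it differs from compound 3 by methyl in place of hydrogen on an aromatic carbon. This is the same kind of change as in compound 2, but the surroundings differ: in compound 2 the methyl enters next to the ring nitrogen and para to a fused ring, whereas in compound 4 it enters ortho to a fused ring and opposite the ring nitrogen. Given the step of an at least 19-fold higher number from compound 1 to compound 2 (1.28 log units; beyond the scatter), a step of a 5.1-fold higher number from compound 3 to compound 4 (0.70 log units; beyond the scatter) toward a weaker inhibitor is expected for compound 4, with wide uncertainty since the surroundings differ. In this assay compound 4 is estimated at 8000 nM, expected between 2000 nM and 40000 nM.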

Compound 4, concentration for 50% growth inhibition: 2950 nM
The estimate for compound 4 lay 2.7-fold (0.43 log units) above the measured number, within the range that was stated.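

In this assay, the same methyl in place of hydrogen on an aromatic carbon now gives a 1.9-fold higher number from compound 3 to compound 4 (0.27 log units; within the scatter), so the size of the earlier step does not carry over from one core to the other: the same change on two cores in this assay, an at least 19-fold higher number (1.28 log units; beyond the scatter) from compound 1 to compound 2 and a 1.9-fold higher number (0.27 log units; within the scatter) from compound 3 to compound 4, at least 10-fold (1.00 log units) apart, beyond the scatter of two such steps
Compound 1 stands at a limit of the assay and not at a number, so the earlier step and the gap between the two steps are known only as bounds: the limit of < 10 nM in this assay, at which 1 of the 4 values shown sits.
The two pairs differ both in the core and in the surroundings of the methyl, and they cannot show which of these sets the gap, or how the change would behave on any further core.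

Open, from the compounds shown here alone, is how an ethyl group, a methoxy group, a chlorine atom or an amine on the same aromatic carbon would read on either core in this assay. Also open, going by these compounds, is how each core would read with an amine or a methoxy group in place of the hydroxyl group.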